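A few compounds are considered here, and "the series" means these few. Any claim that something is new, unique, unknown or untested is made for them only; others in the source may bear on it.

Two thiosemicarbazones built on the same core have been measured, and a third awaits testing. Compound 1 `CC1=CC[C@H](C(C)(C)NC(=S)N/N=C/c2ccc(N(C)C)cc2)CC1` carries a dimethylaminophenyl group on the carbon double-bonded to nitrogen; in a functional assay on K562 cells (Homo sapiens) for inhibition, read by sulforhodamine B assay, with a stated time of 48 h (on this read-out higher numbers stand for weaker inhibition of growth and lower numbers for stronger inhibition of growth), compound 1 gives 22600 nM. Compound 2 `CC1=CC[C@H](C(C)(C)NC(=S)N/N=C/c2ccccc2Cl)CC1` carries a chlorophenyl group at that carbon, and in this assay compound 2 gives 5600 nM, the lower of the two numbers; the gap to compound 1 is beyond the usual scatter, so compound 2 stands as the stronger growth inhibitor of the pair.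

Compound 3 `CC1=CC[C@H](C(C)(C)NC(=S)N/N=C/c2ccc(Cl)cc2)CC1` keeps the same atoms joined differently: 4-chlorophenyl in place of 2-chlorophenyl on a carbon with a double bond to nitrogen. Among the measured compounds shown here, no measured pair shows what such a move of the chlorine does, so the step from compound 2 to compound 3 is expected to be small, perhaps none beyond the scatter, with a slight lean toward a weaker inhibition of growth, as a 1.4-fold higher number from compound 2 to compound 3 (0.15 log units; within the scatter). On that basis compound 3 is expected to give about 8000 nM, within a range from 2500 nM to 25000 nM.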

Compound 3, concentration for 50% growth inhibition: 300 nM
Compound 3: the middle estimate sits 27-fold (1.43 log units) above what was measured; the measured number lies below the stated range.
By their numbers in this assay, from the lowest: compound 3; then compound 2; then compound 1.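

Moving the chlorine on the phenyl ring, with the same atoms and the shared core unchanged, has a large effect in this assay, giving a 19-fold lower number from compound 2 to compound 3 (1.27 log units; beyond the scatter) on the scale of growth inhibition. This position is therefore sensitive not only to which group sits on the phenyl ring but to where that group sits, and with 4-chlorophenyl in place the exchange of dimethylamino for chloro on the aromatic carbon gives a 75-fold lower number from compound 1 to compound 3 (1.88 log units; beyond the scatter) as its result. Nothing at hand explains why the 4-chlorophenyl group outperforms the 2-chlorophenyl group so strongly.

The compounds shown leave open whether bromo, methoxy or a carboxylic acid in place of the chloro of the 4-chlorophenyl group would keep this level of growth inhibition. They also leave open whether the gain from 4-chlorophenyl carries over to other cores or other cell lines.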